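This account rests on a few compounds, and the source may have more. Where it says the series, first, only, none or still open, it means among the compounds named here.

Measured so far:
- compound 1, `Cc1cn2cccc(OCc3ccccc3)c2n1`: 62%
- compound 2, `CCOCc1c(C)nc2c(OCc3ccccc3)cccn12`: 84%
- compound 3, `Cc1nc2c(OCc3ccccc3)cccn2c1CS(C)(=O)=O`: 61%

All three were tested in a functional assay on the whole organism with Rattus norvegicus as the target, with a stated time of 4 h, at a dose of 40 mg/kg by the intraperitoneal route; a lower number here means less inhibition, a higher number more inhibition at the dose given (going by the name of the read-out). Compound 2 stands highest of the three: the step of a number 22 percentage points higher from compound 1 to compound 2 (beyond the scatter) and the step of a number 23 percentage points lower from compound 2 to compound 3 (beyond the scatter) both lie beyond the scatter, while a number 1 percentage points lower from compound 1 to compound 3 (within the scatter) does not. Compound 4, `Cc1nc2c(OCc3ccccc3)cccn2c1C`, has not yet been measured; it differs from compound 2 by hydrogen in place of ethoxy on a saturated chain carbon bound to an aromatic carbon. The closest guide is the step of a number 22 percentage points higher from compound 1 to compound 2 (beyond the scatter), which shows what the ethoxymethyl group added over hydrogen; compound 4 keeps only the methyl part of that group. A modest fall from compound 2 is therefore expected, roughly a number 16 percentage points lower from compound 2 to compound 4 (beyond the scatter). Compound 4 is estimated at 68%, within 50% to 84%.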

Compound 4, a percentage reported as inhibition, in the whole organism at one dose (the size of the read-out at that dose, not a potency): 99%
Compound 4: middle estimate off by 31 percentage points, on the low side, outside the stated range (above it).
By their numbers in this assay, from the lowest: compounds 3 and 1 (each within the scatter of the next); then compound 2; then compound 4.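

In this assay, a bare methyl on the aromatic carbon is enough for a large gain, a number 37 percentage points higher from compound 1 to compound 4 (beyond the scatter), so the ethoxymethyl group of compound 2 is not needed for a high number. Lengthening that methyl lowers the number, since hydrogen in place of ethoxy on the saturated chain carbon gives a number 15 percentage points higher from compound 2 to compound 4 (beyond the scatter) and hydrogen in place of methylsulfonyl gives a number 38 percentage points higher from compound 3 to compound 4 (beyond the scatter). No measurement at hand accounts for this order. From the compounds shown here alone, it remains open whether a plain ethyl chain or an aminomethyl group at this place would hold the number near that of compound 4, at 99%.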